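A Quinoline Ester Series: Replacing Chloro with Benzyl(ethyl)amino

The source may hold more compounds than are shown below. What is called first, only, known or untested is meant among the compounds shown, and "the series" means these compounds.

Three compounds sharing a quinoline-type core carrying a phenyl group have been tested in an assay on brain with Translocator protein (Rattus norvegicus) as the target; a higher number here means a weaker inhibitor, a lower number a stronger inhibitor. Compound 1, `Cc1nc2ccccc2c(-c2ccccc2)c1C(=O)N(C)c1ccccc1`, carries an amide instead of an ester; in this assay compound 1 reaches only the limit > 10000 nM, which is a limit of the measurement and not a number. Compound 2, `CCOC(=O)c1c(Cl)nc2ccccc2c1-c1ccccc1`, gives 3700 nM in this assay. Compound 3, `CCOC(=O)c1c(CN2CCc3ccccc3C2)nc2ccccc2c1-c1ccccc1`, gives 1190 nM in this assay. Among the two compounds with a real number, compound 2 stands at the higher one, and the gap down to compound 3 lies beyond the usual scatter.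

Compound 4, `CCOC(=O)c1c(N(CC)Cc2ccccc2)nc2ccccc2c1-c1ccccc1`, has not yet been measured. It differs from compound 2 in one place: benzyl(ethyl)amino in place of chloro on an aromatic carbon. The chloro of compound 2 gives way to a larger group with one six-membered aromatic ring of carbon only and one hydrogen-bond acceptor, sitting next to the ring nitrogen and ortho to the ethoxycarbonyl group. Compound 3 shows that a bulky nitrogen-containing group at this position can go with a lower number than compound 2, so a lower number is expected for compound 4 as well, beyond the scatter. The step from compound 2 to compound 4 is estimated as a 5.3-fold lower number from compound 2 to compound 4 (0.72 log units; beyond the scatter). Compound 4 is expected to give about 700 nM in this assay, with a likely range from 180 nM to 2800 nM.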

Compound 4, half-maximal inhibitory concentration: 540 nM
Compound 4: middle estimate off by 1.3-fold (0.11 log units), on the high side; low and high end bracket the measured number.
By their numbers in this assay, from the lowest: compound 4; then compound 3; then compound 2. At a limit, above all of these: compound 1.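

In this assay, a step of a 6.9-fold lower number from compound 2 to compound 4 (0.84 log units; beyond the scatter) comes with benzyl(ethyl)amino in place of chloro. Among these compounds, this is the first comparison in the set where a single change can be read directly, and it shows that the position next to the ring nitrogen and ortho to the ethoxycarbonyl group can take a far larger group than chloro, one carrying a six-membered aromatic ring of carbon only, while the number falls rather than rises. No measurement shown here bears on why the number falls with this change.

The compounds shown do not tell whether the lower number depends on the benzyl part, on the ethyl part, or on both together, and a diethylamino group or a plain benzylamino group at this same position would be needed to separate those parts. They also do not tell how far this position can be pushed, for instance with a morpholine ring or a small unsubstituted amine, or whether the same change would give a similar step with a carboxylic acid in place of the ethoxycarbonyl group.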